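A few compounds are considered here, and "the series" means these few. Any claim that something is new, unique, unknown or untested is made for them only; others in the source may bear on it.

Measured so far in a functional assay on MGC-803 cells (Homo sapiens) for inhibition, read by MTT assay, with a stated time of 48 h; a higher number here means a weaker inhibitor, a lower number a stronger inhibitor:

Compound 3 `Cc1ccc(S(=O)(=O)N(Cc2nc3ccccc3[nH]2)c2ccc(F)cc2)cc1` — 34600 nM
Compound 2 `COc1cc(N(Cc2nc3ccccc3[nH]2)S(=O)(=O)c2ccc(F)cc2)cc(OC)c1OC` — 5680 nM
Compound 1 `COc1ccc(CN(c2cc(OC)c(OC)c(OC)c2)S(=O)(=O)c2ccccc2)cc1` — a limit of the assay, > 50000 nM

Of the two numbers reported in this assay, compound 3 holds the higher one, and compound 2 sits a step below it that lies beyond the usual scatter. Compound 1 gives only a limit in this assay, (the limit of > 50000 nM in this assay, at which 1 of the 3 values shown sits), and so adds no number to compare. The unmeasured compound 4 `Cc1ccc(S(=O)(=O)N(Cc2nc3ccccc3[nH]2)c2ccc(Cl)cc2)cc1` differs from compound 3 in one place: chloro in place of fluoro on an aromatic carbon. For the measured compounds named here, no measured pair shows this same change, so there is no measured step from which to read its size; the expectation rests on compound 3 and its value alone. The step of a 1.4-fold lower number from compound 3 to compound 4 (0.14 log units; within the scatter) is expected to be small, leaning toward a lower number but not clearly beyond the scatter of this assay. On that basis compound 4 is estimated at 25000 nM, with a range from 8000 nM to 60000 nM.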

Compound 4, half-maximal inhibitory concentration: 24800 nM
Compound 4: the middle estimate sits 1.0-fold (0.00 log units) above what was measured; the measured number falls inside the stated range.
By their numbers in this assay, from the lowest: compound 2; then compounds 4 and 3 (each within the scatter of the next). At a limit, above all of these: compound 1.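

In this assay, for the compounds shown here, chloro in place of fluoro on an aromatic carbon para to a large group gives a 1.4-fold lower number from compound 3 to compound 4 (0.14 log units; within the scatter), the first measured step at this place. Within this pair, the 4-fluorophenyl and 4-chlorophenyl groups therefore cannot be told apart, so this exchange does not show a clear effect on the number. Nothing available bears on the cause of this small step.

As far as these compounds go, whether an amine, a nitrile or a carboxylic acid at this place would give a step beyond the scatter remains open, since the comparison covers only fluoro and chloro. Also open, from the compounds shown here alone, is whether chloro in place of fluoro would read the same on the core of compound 2 , which gives 5680 nM in this assay.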